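The source may hold more compounds than are shown below. What is called first, only, known or untested is meant among the compounds shown, and "the series" means these compounds.

Working notes on the series. Within the data shown here, the two measured members share one core and differ only in the group on the amide nitrogen. Compound 1 `CCCC(=O)OCSc1ccccc1C(=O)Nc1ccccc1C(N)=O` is measured in an ADME assay on CEM-SS cells (Homo sapiens) for cytotoxicity, read by XTT assay, with a stated time of 6 days (on this read-out lower numbers stand for higher toxicity in this test and higher numbers for lower toxicity in this test), at 50.1 uM. Compound 2 `CCCC(=O)OCSc1ccccc1C(=O)N[C@@H]1CCC[C@H]1C(N)=O` gives in this assay 43.7 uM. On these two numbers compound 2 stands level with compound 1; the gap between them is within the scatter, so nothing separates them on this read-out. Among the measured compounds shown here, compound 3 `CCCC(=O)OCSc1ccccc1C(=O)NCC(=O)NC(C)C` has no measurement yet. Its difference from compound 2 is (isopropylcarbamoyl)methyl in place of 2-carbamoylcyclopentyl on an amide-type nitrogen. For the measured compounds named here, no step between measured compounds is available, and the two measured members, with unlike groups on that nitrogen, come out alike. The step from compound 2 to compound 3 is therefore expected to be small, a 1.0-fold higher number from compound 2 to compound 3 (0.01 log units; within the scatter), with no direction beyond the scatter. Compound 3 is estimated in this assay at 45 uM, within 20 uM to 100 uM.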

Compound 3, half-maximal toxic concentration: 92 uM
Compound 3: the middle estimate sits 2.0-fold (0.31 log units) below what was measured; measured number inside the range.
By their numbers in this assay, from the lowest: compounds 2, 1 and 3 (each within the scatter of the next, the first and the last beyond it).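

In this assay the group on the amide-type nitrogen gives its first step beyond the scatter: (isopropylcarbamoyl)methyl in place of 2-carbamoylcyclopentyl gives a 2.1-fold higher number from compound 2 to compound 3 (0.32 log units; beyond the scatter) (modest), towards lower toxicity in this test. This position is therefore not silent on this read-out, although compound 3 remains within the scatter of compound 1, so only compound 2 is separated from it. Nothing at hand gives a cause for this step.

The change removes the five-membered ring and the two defined stereocentres together, and the compounds shown do not tell which of these goes with the step. Also open, as far as these compounds go, is how a carboxylic acid, a primary amine or a longer chain on this nitrogen would read in this assay.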